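Moving the Carboxyphenyl Attachment Point on a Shared Core

This account rests on a few compounds, and the source may have more. Where it says the series, first, only, none or still open, it means among the compounds named here.

Of the compounds shown here, two have so far been measured in a functional assay on OVCAR-3 cells (Homo sapiens) for cytotoxicity; on this read-out higher numbers stand for weaker inhibition of growth and lower numbers for stronger inhibition of growth. Compound 1 `CNc1ccc(C(=O)Oc2cc(O/N=[N+](\[O-])N(C)C)c([N+](=O)[O-])cc2[N+](=O)[O-])cc1` gives 2600 nM in this assay. Among the measured compounds shown here, compound 2 `CN(C)/[N+]([O-])=N/Oc1cc(Nc2ccc(C(=O)O)cc2)c([N+](=O)[O-])cc1[N+](=O)[O-]` gives 5500 nM in this assay, the higher of the two numbers; its only neighbour is compound 1, whose number is lower by a margin beyond the usual scatter, so compound 2 is the weaker of the pair at slowing the growth of these ovarian cancer cells.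

Compound 3 `CN(C)/[N+]([O-])=N/Oc1cc(Nc2cccc(C(=O)O)c2)c([N+](=O)[O-])cc1[N+](=O)[O-]` has not yet been measured. It differs from compound 2 in a single place: 3-carboxyphenyl in place of 4-carboxyphenyl on a nitrogen on an aromatic ring. The two have the same atoms, joined differently, so the change is a rearrangement rather than an addition or removal.

For the measured compounds named here, no measured pair shows a step of this kind, so there is nothing among the measured compounds to anchor a direction. In the absence of such an anchor, a change no larger than the usual scatter is expected, in either direction: no change at the digits printed from compound 2 to compound 3 (within the scatter). Compound 3 is therefore expected to give about 5500 nM in this assay, with a likely range from 2000 nM to 15000 nM.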

Compound 3, concentration for 50% growth inhibition in the OVCAR-3 assay: 3900 nM
Compound 3: the middle estimate sits 1.4-fold (0.15 log units) above what was measured; the range from low to high includes it.
By their numbers in the OVCAR-3 assay, from the lowest: compounds 1, 3 and 2 (each within the scatter of the next, the first and the last beyond it).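

In the OVCAR-3 assay, 3-carboxyphenyl in place of 4-carboxyphenyl on a nitrogen on an aromatic ring gives a 1.4-fold lower number from compound 2 to compound 3 (0.15 log units; within the scatter), so this first step of its kind does not tell the two arrangements of the same atoms apart on this read-out. In a physicochemical assay for solubility, in phosphate buffer, at 37 degrees C (on this read-out lower numbers stand for lower solubility and higher numbers for higher solubility), compound 2 gives > 3000000 nM, which is a limit of the assay and not a number. In the physicochemical assay compound 3 gives > 2000000 nM, which is also a limit of the assay and not a number.

As far as these compounds go, the step between these two compounds in the physicochemical assay cannot be read from two limits, so any difference in solubility between them stays unknown. Also open, from the compounds shown here alone, is whether a different group on this same nitrogen, such as a plain phenyl ring or a phenyl ring carrying an amide in place of the carboxylic acid, would stand apart from compound 2 in the OVCAR-3 assay by more than the usual scatter.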